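Changing the Linker Geometry From Z to E

The source may report more compounds than this note shows. Statements on the series, on what has been measured and on what is new or still open speak of the compounds shown alone.

Compound 1, `CCCCCCCCC#Cc1cn(C/C=C/CN2C(=O)c3ccccc3C2=O)c(=O)[nH]c1=O`, and compound 2, `O=C1c2ccccc2C(=O)N1C/C=C\Cn1cc(C#CCCc2ccccc2)c(=O)[nH]c1=O`, share the same core and differ in the group on the alkyne and in the geometry of the alkene linker. In a functional assay on HepG2 cells (Homo sapiens) for antiproliferative activity, read by MTT assay, with a stated time of 3 days (on this read-out higher numbers stand for weaker inhibition and lower numbers for stronger inhibition), compound 1 gives 43000 nM. Compound 2 stands only at a limit of the assay: in this assay compound 2 gives > 100000 nM. This is the limit of > 100000 nM in this assay, at which 1 of the 2 values shown sits. For the measured compounds named here, compound 3, `O=C1c2ccccc2C(=O)N1C/C=C/Cn1cc(C#CCCc2ccccc2)c(=O)[nH]c1=O`, has not yet been measured. the two compounds have the same atoms and bonds and differ only in configuration as drawn: 1 of 1 stereo elements differ; a double bond is drawn Z in compound 2 and E in compound 3 No step between two measured compounds isolates this change, so its direction and size cannot be read from the data. Compound 1, however, with its E-configured linker, gives 43000 nM, which shows that a compound of this series and geometry can record a number within the working range. Compound 3 is therefore expected to show a step of an at least 1.6-fold lower number from compound 2 to compound 3 (0.22 log units; that floor lies within the scatter) toward stronger inhibition, though with wide uncertainty. In this assay compound 3 is expected to give about 60000 nM, within a range from 20000 nM to 200000 nM.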

Compound 3, half-maximal inhibitory concentration: 7300 nM
Compound 3: the middle estimate sits 8.2-fold (0.91 log units) above what was measured; the measured number lies below the stated range.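

Compound 2 stands at a limit of the assay and not at a number: the limit of > 100000 nM in this assay, at which 1 of the 3 values shown sits. In this assay the linker geometry alone now shows a step that can be read, an at least 13-fold lower number from compound 2 to compound 3 (1.13 log units; beyond the scatter), and this step belongs to the double bond because nothing else changes: the fact that compounds 2 and 3 differ only in the configuration as drawn. With the E linker in both compounds, the group on the alkyne also counts, since phenyl in place of hexyl on a saturated chain carbon, two bonds along the chain from a triple-bonded carbon, gives a 5.9-fold lower number from compound 1 to compound 3 (0.77 log units; beyond the scatter).

On these data alone, the geometry step is only a floor, so its full size stays open, as does whether it would hold with hexyl in place of phenyl. Also open, as far as these compounds go, is how the number would move with an amine or a carboxylic acid on the phenyl ring, or with a longer chain joining the phenyl to the alkyne.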